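Working notes: aryl amide changes and cell growth inhibition

This account rests on a few compounds, and the source may have more. Where it says the series, first, only, none or still open, it means among the compounds named here.

Measured so far:
- compound 1, `O=C(Nc1ccc(Cl)c(-c2nnc3c(Cl)cccn23)c1)c1ccc(Cl)cc1`, in a functional assay on MDA-MB-468 cells (Homo sapiens) for antiproliferative activity, read by MTT assay, with a stated time of 72 h (a higher number here means a weaker inhibitor, a lower number a stronger inhibitor), gives > 100000 nM, which is a limit of the assay and not a number.
- compound 2, `CS(=O)(=O)c1ccc(C(=O)Nc2ccc(Cl)c(-c3nnc4c(Cl)cccn34)c2)cc1`, in this assay gives > 100000 nM, again a limit of the assay.
- compound 3, `O=C(Nc1ccc(Cl)c(-c2nnc3c(Cl)cccn23)c1)c1ccc(Cl)cc1Cl`, in this assay gives 21600 nM, the only number in the set.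

Compound 4, `CS(=O)(=O)c1ccc(C(=O)Nc2ccc(Cl)c(-c3nnc4c(Cl)cccn34)c2)c(Cl)c1`, is still to be measured in this assay.

Compound 3 differs from compound 1 by chloro in place of hydrogen on an aromatic carbon, and this gives an at least 4.6-fold lower number from compound 1 to compound 3 (0.66 log units; beyond the scatter). From compound 2 the step is an at least 4.6-fold lower number from compound 2 to compound 3 (0.66 log units; beyond the scatter). Both of these are readable only as a floor, because of the limit of > 100000 nM in this assay, at which 2 of the 3 values shown sit.

The change from compound 3 to compound 4 is methylsulfonyl in place of chloro on an aromatic carbon. The same change has been made once before, from compound 1 to compound 2, as methylsulfonyl in place of chloro on an aromatic carbon, and there it gave a step that the two limits leave unreadable from compound 1 to compound 2. The two settings are the same kind of change rather than the same: in compound 1 the place is para to a large group, while in compound 3 it is also meta to a chloro group (1 heavy atom).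

So the earlier step gives no size to carry over. The step to compound 4 is therefore expected to be roughly a 2.1-fold higher number from compound 3 to compound 4 (0.32 log units; beyond the scatter), resting on the limit given by compound 2 and on an at least 4.6-fold lower number from compound 2 to compound 3 (0.66 log units; beyond the scatter) as the only anchors. Compound 4 is estimated at 45000 nM in this assay, with a likely range from 15000 nM to 150000 nM.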

Compound 4, half-maximal inhibitory concentration: > 100000 nM
Compound 4: a limit, no number (the forecaster's own chance of this, stated with the estimate: 35%); at least 2.2-fold (0.34 log units) between middle value and limit.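

In this assay, methylsulfonyl in place of chloro, on an aromatic carbon meta to a chloro group and para to a large group, gives an at least 4.6-fold higher number from compound 3 to compound 4 (0.66 log units; beyond the scatter), so in the one setting with a measured starting value the change takes the series back to the assay limit. The steps from compound 1 to compound 2 and from compound 2 to compound 4 cannot be read, and the step to compound 4 stands only as a floor, because each of these ends on a limit and the two unreadable steps also start from one: the limit of > 100000 nM in this assay, at which 3 of the 4 values shown sit. This shows that the change is unfavourable on the ring of compound 3, but with a single readable case it does not show how large the loss is, or whether it would carry over to the ring of compound 1, where no loss can be seen from a starting point that is already a limit.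

From the compounds shown here alone, only compound 3 gives a number, so how much of its activity depends on the chloro group that methylsulfonyl replaces remains open. Also open, going by these compounds, is whether an amine, a carboxylic acid or a longer alkyl chain at that same aromatic carbon would keep a readable number in this assay.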